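Methyl replacing phenyl on a saturated ring carbon

The source may hold more compounds than are shown below. What is called first, only, known or untested is meant among the compounds shown, and "the series" means these compounds.

Measured so far:
compound 1, `COc1ccc(C2=NN(C(=O)NS(=O)(=O)c3ccc(Cl)cc3)CC2C)c(OC)c1`, gives 16.5% in a functional assay on the whole organism (strain albino) for inhibition, with Rattus norvegicus as the target, read by paw edema, with stated times of 30 min and 3 h, at a dose of 25 mg/kg by the intraperitoneal route; on this read-out higher numbers stand for more inhibition at the one dose given (going by the name of the read-out) and lower numbers for less inhibition
compound 2, `COc1ccc(C2=NN(C(=O)NS(=O)(=O)c3ccc(C)cc3)CC2c2ccccc2)c(OC)c1`, gives 4.83% in this assay

Compound 2 stands lowest of the two numbers; its nearest neighbour, compound 1, lies higher by a gap beyond the usual scatter. Compound 3, `COc1ccc(C2=NN(C(=O)NS(=O)(=O)c3ccc(C)cc3)CC2C)c(OC)c1`, is not yet measured. Its change from compound 2 is methyl in place of phenyl on a saturated ring carbon. Among the measured compounds shown here, no step between measured compounds isolates this change; compound 1 carries the same methyl but differs elsewhere, so its number gives only a hint. In this assay an upward step is expected, roughly at the edge of the scatter, a number 7.2 percentage points higher from compound 2 to compound 3 (within the scatter). Compound 3 is estimated at 12%, with a range from 2% to 24%.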

Compound 3, a percentage reported as inhibition, in the whole organism at one dose (the size of the read-out at that dose, not a potency): 25.2%
Compound 3: the middle estimate sits 13.2 percentage points below what was measured, and the stated range ends below it.
By their numbers in this assay, from the lowest: compound 2; then compounds 1 and 3 (each within the scatter of the next).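

In this assay the saturated ring carbon now has a one-place reading: methyl in place of phenyl gives a number 20.4 percentage points higher from compound 2 to compound 3 (beyond the scatter) and so this position responds to the change. On the aromatic carbon, methyl in place of chloro gives a number 8.7 percentage points higher from compound 1 to compound 3 (within the scatter) and so these two groups are not told apart at this dose. Nothing available bears on the reason for either step. Open, going by these compounds, is whether ethyl or a longer chain on the saturated ring carbon, or an amine on the aromatic carbon, would hold the level of compound 3.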